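Hydroxy added to the phenol of compound 2

The source may hold more compounds than are shown below. What is called first, only, known or untested is meant among the compounds shown, and "the series" means these compounds.

Compound 2 `Oc1ccccc1/C=N/c1cc2ccccc2nc1-c1ccccc1F` gives 34300 nM in a functional assay on SK-OV-3 cells (Homo sapiens) for cytotoxicity, read by MTT assay, with a stated time of 48 h; a higher number here means a weaker inhibitor, a lower number a stronger inhibitor. Going by the values given here, of the two numbers so far it is the higher figure, but the gap to compound 1 `COc1ccc(/C=N/c2cc3ccccc3nc2-c2ccccc2F)c(O)c1`, which gives 32700 nM, is within the scatter, so the two stand level. Among the compounds with values here, the only measured step, a 1.0-fold higher number from compound 1 to compound 2 (0.02 log units; within the scatter), puts hydrogen in place of methoxy on an aromatic carbon and lies within the scatter.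

Compound 3 `Oc1cccc(/C=N/c2cc3ccccc3nc2-c2ccccc2F)c1O` is not yet measured. It differs from compound 2 by hydroxy in place of hydrogen on an aromatic carbon. The step from compound 1 to compound 2 is the only one on record, and it concerns a different exchange; it bears on the present change only in that a change on this ring moved nothing beyond the scatter. Within the data shown here, no step shows what an entering hydroxy does, so no move beyond the scatter is expected in this assay. For compound 3 the estimate is 30000 nM, with a range from 12000 nM to 80000 nM. The expected step is a 1.1-fold lower number from compound 2 to compound 3 (0.06 log units; within the scatter).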

Compound 3, half-maximal inhibitory concentration: 23600 nM
Beside the measured number, compound 3's estimate is 1.3-fold (0.10 log units) above it, within the range that was stated.
By their numbers in this assay, from the lowest: compounds 3, 1 and 2 (each within the scatter of the next).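

In this assay, going by these compounds alone, hydroxy entering on an aromatic carbon ortho to a hydroxy group and meta to a large group gives a 1.5-fold lower number from compound 2 to compound 3 (0.16 log units; within the scatter) and so adds a first reading for an entering hydroxy, which stays inside the scatter at this position. The wider exchange of 2,3-dihydroxyphenyl in place of 2-hydroxy-4-methoxyphenyl gives a 1.4-fold lower number from compound 1 to compound 3 (0.14 log units; within the scatter) and also stays inside the scatter, so compound 1, compound 2 and compound 3 stand level. No measurement on hand speaks to the reason for these numbers.

As far as these compounds go, whether an amine or a carboxylic acid at this same position would carry the number beyond the scatter remains open. Also open, from the compounds shown here alone, is whether any change on the shared core outside this ring would do so.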